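The compounds below may be only part of what the source reports. "The series", "measured", "known", "first", "only" and "open" are said of these compounds alone.

Series notes. Among the measured compounds shown here, compound 1 `CC(=O)OC1C[C@@H]2CCCC[C@@H]2[C@H]1/C=C/c1ccc(-c2cccc(F)c2)cn1` gives 67 nM in an assay on cell membranes for displacement of a labelled ligand from proteinase-activated receptor 1 (Homo sapiens), read by scintillation counting, with a stated time of 60 min (a lower number here means a stronger inhibitor, a higher number a weaker inhibitor), the lowest of the three numbers so far. Compound 2 `CN(C)C(=S)OC1C[C@@H]2CCCC[C@@H]2[C@H]1/C=C/c1ccc(-c2cccc(F)c2)cn1` gives 120 nM in this assay, and compound 3 `COC(=O)NC1C[C@@H]2CCCC[C@@H]2[C@H]1/C=C/c1ccc(-c2cccc(F)c2)cn1` gives 980 nM. The step of a 1.8-fold higher number from compound 1 to compound 2 (0.25 log units; within the scatter) stays within the scatter, whereas a 15-fold higher number from compound 1 to compound 3 (1.17 log units; beyond the scatter) and an 8.2-fold higher number from compound 2 to compound 3 (0.91 log units; beyond the scatter) are clearly beyond it. Compound 4 `CC(=O)NC1C[C@@H]2CCCC[C@@H]2[C@H]1/C=C/c1ccc(-c2cccc(F)c2)cn1` differs from compound 1 by acetamido in place of acetoxy on a saturated ring carbon. For the measured compounds named here, the step that bears most on this change is the one to compound 3, where a group with one hydrogen-bond donor likewise replaced acetoxy and gave a 15-fold higher number from compound 1 to compound 3 (1.17 log units; beyond the scatter). A weaker binder than compound 1 is therefore expected. For compound 4 the expected step is a 5.2-fold higher number from compound 1 to compound 4 (0.72 log units; beyond the scatter). Compound 4 is estimated at 350 nM, with a range of 120 nM to 1000 nM.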

Compound 4, half-maximal inhibitory concentration: 53 nM
Estimate against measurement, compound 4: 6.6-fold (0.82 log units) above; the measured number lies below the stated range.
By their numbers in this assay, from the lowest: compounds 4, 1 and 2 (each within the scatter of the next, the first and the last beyond it); then compound 3.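

On this saturated ring carbon, acetamido in place of acetoxy brings in a hydrogen-bond donor with no readable loss, a 1.3-fold lower number from compound 1 to compound 4 (0.10 log units; within the scatter), so the donor alone does not go with the weaker number of compound 3. The large change instead tracks methyl in place of methoxy on the carbonyl carbon, an 18-fold lower number from compound 3 to compound 4 (1.27 log units; beyond the scatter), and the amide also edges past the group of compound 2, a 2.3-fold lower number from compound 2 to compound 4 (0.35 log units; beyond the scatter). No measurement at hand explains these steps.

Going by these compounds, whether a free amine or a longer chain such as propionamido keeps this level of binding stays open. So does the effect of a methyl on the amide nitrogen.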